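The source may report more compounds than this note shows. Statements on the series, on what has been measured and on what is new or still open speak of the compounds shown alone.

Measured compounds:
compound 1 `CC1=CC[C@H](C(C)(C)NC(=S)N/N=C/c2ccccc2Cl)CC1` — > 100000 nM (a limit)
compound 2 `CC1=CC[C@H](C(C)(C)NC(=S)N/N=C/c2ccc(Cl)cc2)CC1` — 97400 nM

In a functional assay on NCI/ADR-RES cells (Homo sapiens) for inhibition, read by sulforhodamine B assay, with a stated time of 48 h (on this read-out higher numbers stand for weaker inhibition of growth and lower numbers for stronger inhibition of growth), compound 1 `CC1=CC[C@H](C(C)(C)NC(=S)N/N=C/c2ccccc2Cl)CC1` reaches only the assay limit, > 100000 nM. Going by the values given here, compound 2 `CC1=CC[C@H](C(C)(C)NC(=S)N/N=C/c2ccc(Cl)cc2)CC1` gives 97400 nM, the only number in the set. The step of an at least 1.0-fold lower number from compound 1 to compound 2 (0.01 log units; that floor lies within the scatter) lies within the scatter, and the limit of > 100000 nM in this assay, at which 1 of the 2 values shown sits, marks where compound 1 sits, so the two chlorophenyl compounds cannot be separated on these numbers.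

Compound 3 `CC1=CC[C@H](C(C)(C)NC(=S)N/N=C/c2ccco2)CC1` is not yet measured. It differs from compound 2 in one place: furan-2-yl in place of 4-chlorophenyl on a carbon with a double bond to nitrogen. Among the compounds with values here, no measured step bears directly on this exchange; the single measured step concerned the position of the chlorine on the phenyl ring and was within the scatter, and both measured compounds sit at or near the limit of this assay. The expected step is therefore none beyond the scatter, a 1.0-fold higher number from compound 2 to compound 3 (0.01 log units; within the scatter). Compound 3 is estimated at 100000 nM, with a range from 40000 nM to 250000 nM, and a considerable chance that only a limit is reported.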

Compound 3, concentration for total growth inhibition: 14100 nM
For compound 3 the middle estimate is 7.1-fold (0.85 log units) above the measured one; the whole stated range lies above it.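

The group on the carbon with a double bond to nitrogen now proves able to move the read-out in this assay, which moving the chlorine around the phenyl ring had not shown. Furan-2-yl in place of 4-chlorophenyl gives a 6.9-fold lower number from compound 2 to compound 3 (0.84 log units; beyond the scatter), so the first change of ring type at this place produces the first step beyond the scatter in the series. Furan-2-yl in place of 2-chlorophenyl gives an at least 7.0-fold lower number from compound 1 to compound 3 (0.85 log units; beyond the scatter), and this size is only a floor, as compound 1 stands at a limit: the limit of > 100000 nM in this assay, at which 1 of the 3 values shown sits.

The exchange removes the chlorine and also replaces a six-membered aromatic ring of carbon only with a five-membered aromatic ring with 1 hetero atom, so the compounds shown cannot assign the step to either the chlorine, the ring size or the oxygen. Going by these compounds, a plain phenyl group or a thiophen-2-yl group at the same place would separate these readings, and how far the gain extends beyond furan-2-yl remains open.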